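This account rests on a few compounds, and the source may have more. Where it says the series, first, only, none or still open, it means among the compounds named here.

Of the compounds shown here, three of one shared core have so far been tested in an ADME assay on Vero cells (Chlorocebus sabaeus) for cytotoxicity, read by resazurin assay, with a stated time of 72 h; a lower number here means that less compound is tolerated, a higher number that more compound is tolerated. Compound 1 `CC(C)(C)c1ccc(C(=O)/C=C/c2ccc([N+](=O)[O-])o2)cc1` gives > 100000 nM, which is a limit of this assay rather than a number. Compound 2 `O=C(/C=C/c1ccc([N+](=O)[O-])o1)c1ccc(-n2ccnc2)cc1` likewise gives > 100000 nM, again a limit and not a measured value. Going by the values given here, compound 3 `O=C(/C=C/c1ccc([N+](=O)[O-])o1)c1cccc(Br)c1` is the one member with an actual number, giving 68800 nM in this assay. Among the compounds with values here, the only step between measured compounds that differ in one place, a step that the two limits leave unreadable from compound 1 to compound 2, cannot be read because the limit of > 100000 nM in this assay, at which 2 of the 3 values shown sit, covers both of its ends.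

Compound 4 `Cc1cccc(C(=O)/C=C/c2ccc([N+](=O)[O-])o2)c1` is the next member to be measured. It differs from compound 3 by methyl in place of bromo on an aromatic carbon. Within the data shown here, no measured step covers this exchange, and the single measured step between compound 1 and compound 2 has no readable size, so nothing transferable is at hand. Compound 4 is therefore expected to show a step of a 1.3-fold higher number from compound 3 to compound 4 (0.12 log units; within the scatter) relative to compound 3, a change of a size that stays within the usual scatter, with some chance that the value comes back only as a limit. Compound 4 is estimated at 90000 nM, with an expected range from 40000 nM to 200000 nM.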

Compound 4, half-maximal cytotoxic concentration: 55100 nM
Compound 4: middle estimate off by 1.6-fold (0.21 log units), on the high side; the measured number falls inside the stated range.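

Going by these compounds alone, the exchange of bromo for methyl on an aromatic carbon, meta to a large group, gives the first readable step, and in this assay it amounts to a 1.2-fold lower number from compound 3 to compound 4 (0.10 log units; within the scatter). Where compounds 1 and 2 offered only limits, this pair gives two actual numbers, and they cannot be told apart: at this position, the assay does not separate bromo from methyl. The two groups match in heavy-atom count, rings, hydrogen-bond donors, hydrogen-bond acceptors and net charge, so this result covers only an exchange between groups that are alike in all these counts, and it says nothing about a change in any of them.

From the compounds shown here alone, whether an amine, a carboxylic acid or a longer chain at this same place would give a step beyond the scatter remains open, since neither compound 3 nor compound 4 carries such a group. The step from tert-butyl to 1H-imidazol-1-yl also remains unreadable, and the true values of compound 1 and compound 2 stay unknown: the limit of > 100000 nM in this assay, at which 2 of the 4 values shown sit.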